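The compounds below may be only part of what the source reports. "The series", "measured", "known", "first", "only" and "open" are said of these compounds alone.

Measured in a functional assay on MDA-MB-231 cells (Homo sapiens) for cytotoxicity, read by MTT assay, with a stated time of 72 h; a lower number here means a stronger inhibitor, a higher number a weaker inhibitor:
- compound 1 `COc1ccc(/C=C/c2cc(C)no2)cc1OC` gives 79900 nM
- compound 2 `COc1ccc(/C=C/C(=O)CC(C)=O)cc1OC` gives 43100 nM

Within the data shown here, these two values lie within the scatter of each other, so compound 2 stands level with compound 1 on the numbers so far. Compound 3 `COc1ccc(/C=C/C(=O)CC(C)=O)cc1` carries hydrogen in place of methoxy on an aromatic carbon. Among the measured compounds shown here, the one measured step, a 1.9-fold lower number from compound 1 to compound 2 (0.27 log units; within the scatter), changes a different part of the molecule, so no measurement yet shows what removing this methoxy does. With no evidence for a shift, no change beyond the scatter is expected in this assay. The expected step is a 1.0-fold higher number from compound 2 to compound 3 (0.02 log units; within the scatter). For compound 3 the estimated value is 45000 nM, with an expected range from 18000 nM to 100000 nM.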

Compound 3, half-maximal inhibitory concentration: 25000 nM
Compound 3: middle estimate off by 1.8-fold (0.26 log units), on the high side; measured number inside the range.
By their numbers in this assay, from the lowest: compounds 3, 2 and 1 (each within the scatter of the next, the first and the last beyond it).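

In this assay, taking one methoxy off the aromatic ring and leaving hydrogen there gives a 1.7-fold lower number from compound 2 to compound 3 (0.24 log units; within the scatter). Among these compounds, this is the first measurement at this position, and it shows that compound 3 stays level with compound 2 without this methoxy, ortho to the remaining methoxy group. Nothing measured here offers a reason for the size of this step.

Still open, going by these compounds, is whether an ethoxy group, a fluorine atom or an amine at this place would move the number beyond the scatter. Also open, on these data alone, is what replacing the remaining methoxy with hydrogen would do.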